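An ester isomer on the shared core

The source may report more compounds than this note shows. Statements on the series, on what has been measured and on what is new or still open speak of the compounds shown alone.

Measured in a functional assay (aorta) with Rattus norvegicus as the target; on this read-out lower numbers stand for stronger inhibition and higher numbers for weaker inhibition:
Compound 1 `CC1(C)Oc2ccc(C#N)cc2[C@H](N(CC(=O)O)c2ccccc2)[C@H]1O`: > 100000 nM, a limit
Compound 2 `CCOC(=O)CCCN(c1ccccc1)[C@H]1c2cc(C#N)ccc2OC(C)(C)[C@@H]1O`: > 30000 nM, a limit

In this assay compound 2 is known only by its limit of > 30000 nM. For the measured compounds named here, the one other value, for compound 1, is also a limit, > 100000 nM.

Compound 3 `CCCCOC(=O)CN(c1ccccc1)[C@H]1c2cc(C#N)ccc2OC(C)(C)[C@@H]1O` carries butoxycarbonyl in place of 2-(ethoxycarbonyl)ethyl on a saturated chain carbon bound to a nitrogen on an aromatic ring. Going by the values given here, the only measured step is a step that the two limits leave unreadable from compound 1 to compound 2, so it offers no size or direction to carry over. The two structures have the same atoms, joined differently, and no step beyond the scatter is expected in this assay. The expected change is a number no higher from compound 2 to compound 3 (the limit leaves the size open). The estimated value for compound 3 is 30000 nM, with an expected range of 8000 nM to 100000 nM.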

Compound 3, half-maximal inhibitory concentration: 27000 nM
Beside the measured number, compound 3's estimate is 1.1-fold (0.05 log units) above it, and the stated range covers the measured number.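

For the compounds shown here, compound 3 gives the first number in this assay that is not a limit, so a change at this position can now be given a size. Butyl in place of hydrogen on an oxygen next to a carbonyl group gives an at least 3.7-fold lower number from compound 1 to compound 3 (0.56 log units; beyond the scatter), while the change between the two isomeric esters gives an at least 1.1-fold lower number from compound 2 to compound 3 (0.04 log units; that floor lies within the scatter), which does not separate them. As far as these compounds go, the true size of that second step stays open because compound 2 is known only by a limit: the limit of > 30000 nM in this assay, at which 1 of the 3 values shown sits. From the compounds shown here alone, whether a methyl ester or an amide in this place would read differently also remains open.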